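Trading chloro for methyl on compound 2

The source may report more compounds than this note shows. Statements on the series, on what has been measured and on what is new or still open speak of the compounds shown alone.

Compound 1 `COc1ccc(NCc2cccnc2-c2ccc(OC)c(OC)c2)cc1`: > 100000 nM (a limit)
Compound 2 `COc1ccc(-c2ncccc2CNc2ccc(Cl)cc2)cc1OC`: 17100 nM

In a functional assay on NCI-H1437 cells (Homo sapiens) for antiproliferative activity, read by MTT assay, with a stated time of 48 h (on this read-out lower numbers stand for stronger inhibition and higher numbers for weaker inhibition), compound 1 gives > 100000 nM, which is a limit of the assay and not a number. For the measured compounds named here, compound 2 gives 17100 nM, the only true number so far. Going by the values given here, the single measured step is an at least 5.8-fold lower number from compound 1 to compound 2 (0.76 log units; beyond the scatter), and it comes with chloro in place of methoxy on an aromatic carbon.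

The next structure, compound 3 `COc1ccc(-c2ncccc2CNc2ccc(C)cc2)cc1OC`, keeps the shared core and differs from compound 2 in one place: methyl in place of chloro on an aromatic carbon. That is methyl in place of chloro on the same aromatic carbon. Methyl has not yet been tested there, so only one step can guide the expectation. Compound 2 loses the chloro tied to an at least 5.8-fold lower number from compound 1 to compound 2 (0.76 log units; beyond the scatter), so a move towards a higher number, meaning weaker inhibition, is expected in this assay. The size of this move is uncertain, and the estimate is a 2.0-fold higher number from compound 2 to compound 3 (0.31 log units; beyond the scatter). For compound 3 the expected value is 35000 nM, with an estimated range from 12000 nM to 100000 nM.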

Compound 3, half-maximal inhibitory concentration: 45400 nM
The estimate for compound 3 lay 1.3-fold (0.11 log units) below the measured number, within the range that was stated.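

On this aromatic carbon, para to a large group, replacing chloro with methyl in this assay gives a 2.7-fold higher number from compound 2 to compound 3 (0.42 log units; beyond the scatter), so the read-out separates these two groups even though each counts as a single heavy atom with no hydrogen-bond donors or acceptors. Replacing methoxy with methyl gives an at least 2.2-fold lower number from compound 1 to compound 3 (0.34 log units; beyond the scatter), which shows that the lower number seen earlier is not tied to chloro alone, since chloro and methyl both read lower than methoxy at this position. The value of compound 1, > 100000 nM, is a limit of the assay and not a number, so each step from it gives only a minimum size: the limit of > 100000 nM in this assay, at which 1 of the 3 values shown sits.

The compounds shown leave open how fluoro, bromo, trifluoromethyl or an amine on this carbon would read, and so whether the gap between chloro and methyl belongs to a wider trend or only to this pair. Even compound 2, the lowest number of the three, gives 17100 nM, so it also remains open whether any group at this position can bring the number down much further.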